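The source may report more compounds than this note shows. Statements on the series, on what has been measured and on what is new or still open speak of the compounds shown alone.

Measured in an ADME assay on Jurkat cells (Homo sapiens) for cytotoxicity, read by MTT assay; a lower number here means a stronger inhibitor, a higher number a weaker inhibitor:
- Compound 1 `C/C(COc1cccc2ccccc12)=N\O`: > 50000 nM, a limit
- Compound 2 `O/N=C(\COc1cccc2ccccc12)c1ccc(Br)cc1`: > 50000 nM, a limit
- Compound 3 `COc1ccc(/C(COc2cccc3ccccc23)=N/O)cc1`: 31800 nM

Compound 2 gives > 50000 nM, which is a limit and not a number. It stands at the limit of > 50000 nM in this assay, at which 2 of the 3 values shown sit.

Compound 4 `O/N=C(\COc1cccc2ccccc12)c1ccc(-c2ccccc2)cc1` has phenyl in place of bromo on an aromatic carbon. Within the data shown here, one measured step bears on this carbon. Methoxy in place of bromo gave an at least 1.5-fold lower number from compound 2 to compound 3 (0.19 log units; that floor lies within the scatter). It is a different group, so it offers only a weak guide. The step expected in this assay is therefore small and toward a lower number, possibly none beyond the scatter: an at least 1.4-fold lower number from compound 2 to compound 4 (0.15 log units; that floor lies within the scatter). For compound 4 the estimated value is 35000 nM, with an expected range from 15000 nM to 70000 nM.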

Compound 4, half-maximal inhibitory concentration: > 50000 nM
Compound 4: no number, only a limit; the forecaster's own chance of this, stated with the estimate: 45%; at least 1.4-fold (0.15 log units) between middle value and limit.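

In this assay compound 4 gives > 50000 nM, which is a limit, so this aromatic carbon now carries a second group, phenyl, that yields no readable number, and the steps between the two limits cannot be read. Phenyl in place of methoxy gives an at least 1.5-fold higher number from compound 3 to compound 4 (0.19 log units; that floor lies within the scatter). Most of the series now sits at one edge of the assay: the limit of > 50000 nM in this assay, at which 3 of the 4 values shown sit.

As far as these compounds go, it remains open whether an amine or a carboxylic acid on this aromatic carbon would give a readable value. From the compounds shown here alone, it also remains open whether methoxy truly separates from bromo and phenyl beyond the scatter.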